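A few compounds are considered here, and "the series" means these few. Any claim that something is new, unique, unknown or untested is made for them only; others in the source may bear on it.

In a functional assay on HL-60 cells (Homo sapiens) for antiproliferative activity, read by MTT assay (a lower number here means a stronger inhibitor, a higher number a weaker inhibitor), compound 1 (`CC[C@H]1O[C@H](COCc2ccccc2)[C@@H](OCc2ccccc2)[C@H](OCc2ccccc2)[C@H]1O`) gives "not active" (no number reported) and compound 3 (`O[C@@H]1[C@@H](O)[C@H](Cc2ccccc2)O[C@H](COCc2ccccc2)[C@H]1O`) gives "not active" (no number reported) as well. Going by the values given here, compound 2 (`C=C[C@@H]1O[C@H](COCc2ccccc2)[C@@H](OCc2ccccc2)[C@H](OCc2ccccc2)[C@H]1O`) gives 11800 nM in this assay and so holds the only number of the three, with no measured neighbour to set it against. Compound 4 (`O[C@@H]1[C@@H](OCc2ccccc2)[C@H](OCc2ccccc2)[C@@H](COCc2ccccc2)O[C@H]1Cc1ccccc1`) has not yet been measured. It differs from compound 2 by benzyl in place of vinyl on a saturated ring carbon. Among the compounds with values here, no measured pair shows what such an exchange does in this assay, so any expectation here rests on thin evidence. With compound 1 at "not active" (no number reported) and compound 3 at "not active" (no number reported) there is no sign of a gain to build on, and a small weakening is the more likely direction, possibly no larger than the usual scatter. A report with no number at all would also not be surprising. The expected change is a 1.3-fold higher number from compound 2 to compound 4 (0.10 log units; within the scatter) and stays modest. In this assay compound 4 is estimated at 15000 nM with the expected range running from 6000 nM to 40000 nM around it.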

Compound 4, half-maximal inhibitory concentration: 8700 nM
For compound 4 the middle estimate is 1.7-fold (0.24 log units) above the measured one; measured number inside the range.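

Setting benzyl in place of vinyl on the saturated ring carbon next to the ring oxygen gives a 1.4-fold lower number from compound 2 to compound 4 (0.13 log units; within the scatter) in this assay, so this pair cannot be told apart. Going by these compounds alone, compound 2 no longer holds the only number, and a measured number at this position is therefore not tied to vinyl: this ring carbon also accepts benzyl, which brings a six-membered aromatic ring. Nothing shown here bears on why the two compounds read alike.

From the compounds shown here alone, what an amine, a carboxylic acid or a longer chain on this ring carbon would do in this assay remains open. Also open is what each benzyloxy group contributes to the reading, since no measured pair shown isolates a change at any of them.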